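Swapping an Acetamido for a Carbamoyl Group

This account rests on a few compounds, and the source may have more. Where it says the series, first, only, none or still open, it means among the compounds named here.

Compound 1 `CN(C)c1ccc(NC(=O)c2cn(Cc3c(F)cccc3Cl)c3ccc(=O)[nH]c3c2=O)cc1` gives 39 nM in an in vitro assay on Sf21 cells for inhibition of high affinity 3',5'-cyclic-AMP phosphodiesterase 7A (Homo sapiens), read by scintillation proximity assay, with a stated time of 30 min; a lower number here means a stronger inhibitor, a higher number a weaker inhibitor.
Compound 2 `CC(=O)Nc1ccc(NC(=O)c2cn(Cc3c(F)cccc3Cl)c3ccc(=O)[nH]c3c2=O)cc1` gives 17 nM in this assay.

Among the compounds with values here, of the two measured compounds, compound 2 has the lowest number, and the only measured step, a 2.3-fold lower number from compound 1 to compound 2 (0.36 log units; beyond the scatter), separates it from compound 1. Compound 3 `NC(=O)c1ccc(NC(=O)c2cn(Cc3c(F)cccc3Cl)c3ccc(=O)[nH]c3c2=O)cc1` is the next compound to be examined. It differs from compound 2 in one place: carbamoyl in place of acetamido on an aromatic carbon. Within the data shown here, no measured step covers this particular exchange; the single step available exchanges a different group at the same place and was only modest in size. Among the measured compounds shown here, with one modest step as the sole guide, a change close to or within the usual scatter is the most reasonable expectation for this assay, with a slight lean toward a higher number. Compound 3 is therefore estimated at 25 nM, in a range from 8 nM to 80 nM, an expected step of a 1.5-fold higher number from compound 2 to compound 3 (0.17 log units; within the scatter).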

Compound 3, half-maximal inhibitory concentration: 10 nM
For compound 3 the middle estimate is 2.5-fold (0.40 log units) above the measured one; measured number inside the range.
By their numbers in this assay, from the lowest: compounds 3 and 2 (each within the scatter of the next); then compound 1.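

At this place on the aromatic ring, para to a large group, acetamido can be exchanged for carbamoyl without a change that stands clear of the usual scatter in this assay, with a 1.7-fold lower number from compound 2 to compound 3 (0.23 log units; within the scatter), so the two groups cannot be told apart here. The exchange for dimethylamino does stand out, with a 3.9-fold lower number from compound 1 to compound 3 (0.59 log units; beyond the scatter), and it points the same way as the earlier step: among these three compounds, both groups containing a carbonyl give lower numbers than dimethylamino, and no compound shown goes against this. No measurement shown here accounts for these differences.

The compounds shown leave open how a carboxylic acid, a nitrile or a longer chain would fare at this place. They also do not tell whether carbamoyl would give a similar number elsewhere on the ring.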